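The source may report more compounds than this note shows. Statements on the series, on what has been measured and on what is new or still open speak of the compounds shown alone.

Three compounds have been measured:

Compound 1, `COc1ccc2c(c1)CCC/C2=N\NCc1nc2ccccc2[nH]1`, gives 63000 nM in a functional assay on MCF7 cells (Homo sapiens) for cytotoxicity, read by MTT assay; on this read-out lower numbers stand for stronger inhibition and higher numbers for weaker inhibition.
Compound 2, `O=[N+]([O-])c1ccc2[nH]c(CNc3nc4ccc(F)cc4s3)nc2c1`, gives 291000 nM.
Compound 3, `COc1ccc2c(c1)CCC/C2=N\NCc1nc2cc([N+](=O)[O-])ccc2[nH]1`, gives 78000 nM.

Compounds 1 and 3 share one core and differ in a single spot: hydrogen in place of nitro on an aromatic carbon. That change made a 1.2-fold lower number from compound 3 to compound 1 (0.09 log units; within the scatter), so the two values cannot be told apart with confidence. Compound 2 is built on a different core; the difference between the two cores is not broken down here. Among the three measured compounds, compound 2 gives the highest number, and its gaps to compound 3 and to compound 1 both lie beyond the usual scatter.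

Compound 4, `Fc1ccc2nc(NCc3nc4ccccc4[nH]3)sc2c1`, is not yet measured. It arises from compound 2 by hydrogen in place of nitro on an aromatic carbon, the same change, at the same place, that turned compound 3 into compound 1. The step is expected to be a 1.2-fold lower number from compound 2 to compound 4 (0.07 log units; within the scatter) because the same change gave a 1.2-fold lower number from compound 3 to compound 1 (0.09 log units; within the scatter). On that basis compound 4 is expected to give about 250000 nM, most likely between 110000 nM and 600000 nM.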

Compound 4, half-maximal inhibitory concentration: 242000 nM
Compound 4: middle estimate off by 1.0-fold (0.01 log units), on the high side, and the stated range covers the measured number.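

In this assay, putting hydrogen in place of nitro on the core of compound 2 gives a 1.2-fold lower number from compound 2 to compound 4 (0.08 log units; within the scatter), so the two values cannot be told apart with confidence. On this evidence, the change carries over from one core to the other, since it leaves the number within the scatter on both: the same change on two cores in this assay, a 1.2-fold lower number (0.09 log units; within the scatter) from compound 3 to compound 1 and a 1.2-fold lower number (0.08 log units; within the scatter) from compound 2 to compound 4, 1.0-fold (0.01 log units) apart, within the scatter of two such steps
For the compounds shown here, this agreement rests on only two cores and on two steps that are both too small to separate from the scatter, so it does not show that the change would behave the same way on any further core, nor does it explain why the steps are so small.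

The compounds shown leave open whether another group at this place on an aromatic carbon, such as an amine or a carboxylic acid, would move the number beyond the scatter. Going by these compounds, it also remains open how the number would respond to a chlorine or a methyl group in place of the fluorine on compound 4.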